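Nitro on the pendant phenyl of compound 1

The source may report more compounds than this note shows. Statements on the series, on what has been measured and on what is new or still open speak of the compounds shown alone.

Measured so far:
compound 1, `O=C1C(O)=C(C(c2ccccc2)c2c(-c3ccccc3)[nH]c3ccccc23)C(=O)c2ccccc21`: 5180 nM
compound 2, `O=C1C(O)=C(C(c2ccc(Cl)cc2)c2c[nH]c3ccccc23)C(=O)c2ccccc21`: 45800 nM

Compound 1 holds the lowest number of the two in a functional assay on ECa-109 cells (Homo sapiens) for cytotoxicity, read by MTT assay, with a stated time of 48 h; a higher number here means a weaker inhibitor, a lower number a stronger inhibitor. Compound 2 differs from it in more than one place, so no single step can be read from the pair; its number is higher, and the gap lies beyond the usual scatter.

Compound 3, `O=C1C(O)=C(C(c2cccc([N+](=O)[O-])c2)c2c(-c3ccccc3)[nH]c3ccccc23)C(=O)c2ccccc21`, keeps the core of compound 1 with one change: nitro in place of hydrogen on an aromatic carbon. For the measured compounds named here, no measured pair isolates this change, so the direction of the step is not anchored by data. Because compound 1 already gives 5180 nM in this assay, and nothing here separates the phenyl substituent effect, a step of no more than the usual scatter is expected in either direction. Compound 3 is expected to give 4500 nM, range 1500 nM to 13000 nM. The expected step of a 1.2-fold lower number from compound 1 to compound 3 (0.06 log units; within the scatter) is estimated to stay within the scatter.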

Compound 3, half-maximal inhibitory concentration: 5830 nM
For compound 3 the middle estimate is 1.3-fold (0.11 log units) below the measured one, and the stated range covers the measured number.
By their numbers in this assay, from the lowest: compounds 1 and 3 (each within the scatter of the next); then compound 2.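

In this assay, for the compounds shown here, the change from phenyl to 3-nitrophenyl gives a 1.1-fold higher number from compound 1 to compound 3 (0.05 log units; within the scatter), the first step that can be read at a single place, and it lies within the scatter. On this aromatic carbon, meta to a large group, a nitro group with its 3 heavy atoms therefore leaves the number indistinguishable from that of compound 1. No measurement shown bears on why this is so.

From the compounds shown here alone, whether an amine or a carboxylic acid at this same place would move the number beyond the scatter remains open, as does the effect of nitro at other places on this ring. Compound 2 differs from compound 1 and compound 3 in more than one place, so those pairs cannot be read as steps, and the contributions of its differences remain unseparated.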